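Methyl for trifluoromethyl on a core that shows no inhibition

The source may report more compounds than this note shows. Statements on the series, on what has been measured and on what is new or still open speak of the compounds shown alone.

Three compounds have been tested in an assay on isolated protein for inhibition of ubiquitin carboxyl-terminal hydrolase 14 (Homo sapiens); a higher number here means a weaker inhibitor, a lower number a stronger inhibitor:
Compound 1 `Nc1nc2ccccn2c1-c1ccc(O)cc1` gives > 100000 nM, which is a limit of the assay.
Compound 2 `Nc1nc2ccc(C(F)(F)F)cn2c1-c1ccc(O)cc1` gives > 100000 nM, also a limit.
Compound 3 `Nc1nc2cc(C(F)(F)F)ccn2c1-c1ccc(O)cc1` gives > 100000 nM, again a limit.

Compound 2 thus stands at the assay's limit, where all three values sit (the limit of > 100000 nM in this assay, at which 3 of the 3 values shown sit). Compound 4 `Cc1ccc2nc(N)c(-c3ccc(O)cc3)n2c1` differs from compound 2 by methyl in place of trifluoromethyl on an aromatic carbon. Among the compounds with values here, the only measured steps, a step that the two limits leave unreadable from compound 1 to compound 2 and a step that the two limits leave unreadable from compound 1 to compound 3, cannot be read in size because both ends are limits, so they give no direction for the change. Since compound 2 sits at > 100000 nM and no measured change to this core has produced a number, compound 4 is expected to give a step that the limit leaves unreadable from compound 2 to compound 4 in this assay, most likely again a limit. The estimate for compound 4 is 150000 nM, with a range from 50000 nM to 500000 nM.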

Compound 4, half-maximal inhibitory concentration: > 100000 nM
Compound 4: a limit, no number (the forecaster's own chance of this, stated with the estimate: 85%); the middle value does not contradict the limit.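

Compound 4 gives > 100000 nM, which is a limit and not a number, so its steps from compound 1 and compound 2 cannot be read. The compounds shown leave open whether any change to the shared core yields a measurable value: the limit of > 100000 nM in this assay, at which 4 of the 4 values shown sit.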